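Swapping the Para Hydrogen for Trifluoromethyl

This account rests on a few compounds, and the source may have more. Where it says the series, first, only, none or still open, it means among the compounds named here.

Compound 1 `CCOC(=O)c1sc2ccc(NCc3c[nH]cn3)cc2c1NC(=O)c1ccccc1` carries an unsubstituted phenyl on its amide. In a functional assay on HeLa cells (Homo sapiens) for antiproliferative activity, read by MTT assay, with a stated time of 48 h (on this read-out lower numbers stand for stronger inhibition of growth and higher numbers for weaker inhibition of growth), compound 1 gives 17900 nM, which stands at the top of the two numbers shown, although the gap to its nearest neighbour is within the scatter. That neighbour is compound 2 `CCOC(=O)c1sc2ccc(NCc3c[nH]cn3)cc2c1NC(=O)c1ccc(OC)cc1`, which has a methoxy in place of hydrogen on an aromatic carbon; in this assay compound 2 gives 12900 nM. The step of a 1.4-fold lower number from compound 1 to compound 2 (0.14 log units; within the scatter) is within the scatter, so the two compounds read alike.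

Compound 3 `CCOC(=O)c1sc2ccc(NCc3c[nH]cn3)cc2c1NC(=O)c1ccc(C(F)(F)F)cc1` differs from compound 1 by trifluoromethyl in place of hydrogen on an aromatic carbon, a trifluoromethyl in place of hydrogen on an aromatic carbon of a six-membered aromatic ring of carbon only, para to a large group, so that phenyl becomes 4-(trifluoromethyl)phenyl. For the measured compounds named here, no measured step puts a trifluoromethyl at this place. Going by the values given here, the only step that bears on the same carbon, a 1.4-fold lower number from compound 1 to compound 2 (0.14 log units; within the scatter), stayed within the scatter, and nothing else in the data speaks for a large move in either direction. The expected step is therefore a 1.2-fold lower number from compound 1 to compound 3 (0.08 log units; within the scatter), not beyond the scatter. For compound 3 in this assay the estimate is 15000 nM, with a range from 5000 nM to 45000 nM.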

Compound 3, concentration for 50% growth inhibition: 16800 nM
Estimate against measurement, compound 3: 1.1-fold (0.05 log units) below; measured number inside the range.
By their numbers in this assay, from the lowest: compounds 2, 3 and 1 (each within the scatter of the next).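

In this assay, replacing phenyl with 4-(trifluoromethyl)phenyl gives a 1.1-fold lower number from compound 1 to compound 3 (0.03 log units; within the scatter), so this second substituent at the carbon para to a large group also produces no readable change. Trifluoromethyl and methoxy, exchanged directly at this place, give a 1.3-fold higher number from compound 2 to compound 3 (0.11 log units; within the scatter), which shows that the two substituted compounds read alike as well as each reading like the unsubstituted compound 1; all three steps among these compounds now stay within the scatter. Nothing in the data explains why this position gives so little response to either group.

The compounds shown leave open whether any group at this carbon can move the number beyond the scatter, for instance an amine, a carboxylic acid or a longer chain such as butoxy. They also leave open whether methoxy or trifluoromethyl would read the same on the other carbons of this ring, and whether the flat response would hold on a core that differs elsewhere, for instance with a carboxylic acid in place of the ethyl ester.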